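Sulfonyl aryl swap on the lactam sulfonamide series

This account rests on a few compounds, and the source may have more. Where it says the series, first, only, none or still open, it means among the compounds named here.

Measured so far in an assay on isolated protein for inhibition of coagulation factor X (Oryctolagus cuniculus), tested at 1 uM; a higher number here means more inhibition at the concentration tested (going by the name of the read-out), a lower number less inhibition:
compound 1 `O=C1[C@@H](NS(=O)(=O)c2cc3ccnc(Cl)c3s2)CCN1Cc1cc2[nH]cccc-2n1` gives 45%
compound 2 `O=C1[C@@H](NS(=O)(=O)c2nc3cc(Cl)ccc3[nH]2)CCN1CCNc1ccncc1` gives 29%
compound 3 `O=C1[C@@H](NS(=O)(=O)c2ccc(-c3ccon3)s2)CCN1Cc1cc2[nH]cccc-2n1` gives 31%

Compound 3 holds the second highest of the three numbers in this assay; its nearest neighbour is compound 2, whose value lies within the scatter of it, and the furthest is compound 1, which sits beyond the scatter above it. Within the data shown here, the one step between measured compounds that touches the sulfonyl aryl group is the step from compound 1 to compound 3, a change of a number 14 percentage points lower from compound 1 to compound 3 (beyond the scatter), modest but real.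

Compound 4 `O=C1[C@@H](NS(=O)(=O)c2nc3cc(Cl)ccc3[nH]2)CCN1Cc1cc2[nH]cccc-2n1` differs from compound 3 in one place: 5-chloro-1H-benzimidazol-2-yl in place of 5-(1,2-oxazol-3-yl)thiophen-2-yl on a sulfonyl sulfur. Among the measured compounds shown here, no measured pair isolates exactly this swap. For the measured compounds named here, compound 2 carries the same 5-chloro-1H-benzimidazol-2-yl on its sulfonyl sulfur but a different group on the lactam nitrogen, and its value against compound 3 shows only two numbers within the scatter of each other. Going by the values given here, the only precedent for swapping the sulfonyl aryl, the step from compound 1 to compound 3, was modest, so a change of similar size in either direction, or none beyond the scatter, is the expectation here.

For compound 4 the estimate in this assay is 35%, with a range of 15% to 55%, an expected step of a number 4 percentage points higher from compound 3 to compound 4 (within the scatter) that stays within the scatter.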

Compound 4, a percentage reported as inhibition, at one concentration (the size of the read-out at that concentration, not a potency): 14%
Compound 4: the middle estimate sits 21 percentage points above what was measured, and the stated range ends above it.
By their numbers in this assay, from the lowest: compound 4; then compounds 2 and 3 (each within the scatter of the next); then compound 1.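

On the sulfonyl sulfur, with the rest of the molecule held constant, 5-chloro-1H-benzimidazol-2-yl gives the lowest reading so far in this assay (a number 17 percentage points lower from compound 3 to compound 4 (beyond the scatter) and a number 31 percentage points lower from compound 1 to compound 4 (beyond the scatter)), so this position can carry a larger change than the earlier a number 14 percentage points lower from compound 1 to compound 3 (beyond the scatter) alone showed. The read-out for this sulfonyl group also depends on the other side of the molecule, since a number 15 percentage points lower from compound 2 to compound 4 (beyond the scatter) when only the group on the saturated chain carbon bound to the ring amide-type nitrogen changes, and the value of compound 2 therefore does not carry over to a compound with a different group there. Nothing available bears on why these steps occur.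

Going by these compounds, it remains open whether the lower reading follows the chlorine or the benzimidazole ring itself, a question that an unsubstituted 1H-benzimidazol-2-yl or a carboxylic acid in place of the chlorine would address. On these data alone, it is also open how the sulfonyl groups of compound 1 and compound 3 behave when paired with the chain of compound 2, which ends in a pyridine ring bearing an amine.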